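Chromone carboxamides and acrylamide in rat inhibition at one dose

The source may report more compounds than this note shows. Statements on the series, on what has been measured and on what is new or still open speak of the compounds shown alone.

Measured compounds:
compound 1 `CN1CCN(C(=O)/C=C/c2coc3ccccc3c2=O)CC1` in a functional assay on the whole organism for inhibition, with Rattus norvegicus as the target, with a stated time of 30 min, at a dose of 1 mg/kg by the intravenous route (a higher number here means more inhibition at the dose given (going by the name of the read-out), a lower number less inhibition), gives 0%
compound 2 `Cc1c(C(=O)Nc2nnn[nH]2)oc2ccccc2c1=O` in this assay gives 70%
compound 3 `CN(C(=O)c1cc(=O)c2ccccc2o1)c1nnn[nH]1` in this assay gives 0%

Compound 2 holds the highest number of the three. Its nearest neighbour on the numbers is compound 1, and its furthest is compound 3, and both lie beyond the scatter below it. Among the measured compounds shown here, no single-point step between measured compounds is available, so nothing in the measured set shows how the read-out answers a small change on the core of compound 2.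

Compound 4 `CNc1c(C(=O)Nc2nnn[nH]2)oc2ccccc2c1=O` is not yet measured. It differs from compound 2 in one place: methylamino in place of methyl on an aromatic carbon. The measured compounds give no guidance on this exchange. The expectation for a number 20 percentage points lower from compound 2 to compound 4 (beyond the scatter) is therefore a step of moderate size downward, with a wide range that keeps retention of the level of compound 2 possible. Compound 4 is estimated at 50% in this assay, with a range from 10% to 85%.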

Compound 4, a percentage reported as inhibition, in the whole organism at one dose (the size of the read-out at that dose, not a potency): 100%
Compound 4: middle estimate off by 50 percentage points, on the low side; the whole stated range lies below it.
By their numbers in this assay, from the lowest: compounds 1 and 3 (each within the scatter of the next); then compound 2; then compound 4.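

Exchanging methyl for methylamino on the aromatic carbon two atoms from the ring oxygen gives a number 30 percentage points higher from compound 2 to compound 4 (beyond the scatter) in this assay, the first single-place step available on the core of compound 2. This position therefore accepts a group larger than methyl without loss of the read-out, and the change raises it at the dose given, which says nothing about potency. Nothing measured on any property of these compounds bears on this rise, so it stays an observation without an assigned cause.

Going by these compounds, whether an unsubstituted amine, dimethylamino or a longer chain such as ethylamino would hold the level of compound 4 remains open. Also open, on these data alone, is whether a hydroxyl or methoxy group at this position would do the same, which would show if the nitrogen itself matters.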